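The source may hold more compounds than are shown below. What is called first, only, known or untested is meant among the compounds shown, and "the series" means these compounds.

Values in an assay on Sf21 cells for inhibition of ubiquitin carboxyl-terminal hydrolase 7 (Homo sapiens), read by spectrophotometry, with stated times of 30 min and 2 h (on this read-out lower numbers stand for stronger inhibition and higher numbers for weaker inhibition), for the three measured compounds:

Compound 1, `O=c1c2cnn(-c3ccc(F)cc3)c2ncn1CC1(O)CCN(Cc2ccccc2F)CC1`, gives 9800 nM.
Compound 2, `O=c1c2cnn(-c3ccc(F)cc3)c2ncn1CC1(O)CCN(Cc2ccc(Cl)cc2Cl)CC1`, gives 3300 nM.
Compound 3, `O=c1c2cnn(-c3ccc(F)cc3)c2ncn1CC1(O)CCN(Cc2ccc(Br)cc2Cl)CC1`, gives 1900 nM.

Compound 3 holds the lowest of the three numbers in this assay; its step from compound 2 is within the scatter, while its step from compound 1 is beyond it. Compound 4, `N#Cc1cc(Cl)ccc1CN1CCC(O)(Cn2cnc3c(cnn3-c3ccc(F)cc3)c2=O)CC1`, differs from compound 3 in one place: 4-chloro-2-cyanophenyl in place of 4-bromo-2-chlorophenyl on a saturated chain carbon bound to an amine nitrogen in a ring.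

Among the compounds with values here, two measured steps bear on this change. The step of a 1.7-fold lower number from compound 2 to compound 3 (0.24 log units; within the scatter) shows that exchanging bromo and chloro on an aromatic carbon is within the scatter, and the steps of a 3.0-fold lower number from compound 1 to compound 2 (0.47 log units; beyond the scatter) and a 5.2-fold lower number from compound 1 to compound 3 (0.71 log units; beyond the scatter) show that the group on this chain carbon can move the number modestly. Within the data shown here, no measured compound carries a nitrile on this ring, so that part of the change has no precedent here. The account therefore expects compound 4 to stay within the scatter of compound 3, estimated as a 1.3-fold higher number from compound 3 to compound 4 (0.12 log units; within the scatter). Compound 4 is estimated at 2500 nM, with a range from 800 nM to 8000 nM.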

Compound 4, half-maximal inhibitory concentration: 11400 nM
Beside the measured number, compound 4's estimate is 4.6-fold (0.66 log units) below it, and the stated range ends below it.
By their numbers in this assay, from the lowest: compounds 3 and 2 (each within the scatter of the next); then compounds 1 and 4 (each within the scatter of the next).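

In this assay the group on the saturated chain carbon bound to an amine nitrogen in a ring tolerates an exchange of bromo and chloro, but not every exchange on the ring: a 6.0-fold higher number from compound 3 to compound 4 (0.78 log units; beyond the scatter) and a 3.5-fold higher number from compound 2 to compound 4 (0.54 log units; beyond the scatter) are both beyond the scatter. The 4-chloro-2-cyanophenyl group also gives up the advantage that the two dihalogenated rings held over the 2-fluorophenyl ring, with a 1.2-fold higher number from compound 1 to compound 4 (0.07 log units; within the scatter) within the scatter. Nothing measured on these compounds explains this loss.

The compounds shown leave open whether the loss belongs to the nitrile alone or would also follow from a methoxy group or a primary amide on this ring. They also leave open how a 4-chlorophenyl ring with no second substituent would compare.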